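This account rests on a few compounds, and the source may have more. Where it says the series, first, only, none or still open, it means among the compounds named here.

Measured so far in the series:
- compound 1, `CS(=O)(=O)c1ccc(C(=O)NCCC(=O)N2CCc3ccccc32)cc1[N+](=O)[O-]`: > 27000 nM
- compound 2, `Cc1ccc(N2CCN(C(=O)C3CCN(C(=O)c4ccc(S(C)(=O)=O)c([N+](=O)[O-])c4)CC3)CC2)cc1`: > 27000 nM
- compound 3, `CN(Cc1ccccc1F)C(=O)C1CCN(C(=O)c2ccc(S(C)(=O)=O)c([N+](=O)[O-])c2)CC1`: > 27000 nM

In an ADME assay on HepG2 cells (Homo sapiens) for cytotoxicity, read by CellTiter-Glo and ATP content, with a stated time of 72 h (a lower number here means that less compound is needed, a higher number that more compound is needed for the effect), compound 1 returns only a limit, > 27000 nM. Compound 2 likewise returns a limit in this assay, > 27000 nM. Compound 3 also reaches no number in this assay and stands at > 27000 nM. Among the compounds with values here, compound 3 therefore cannot be placed relative to the others by a value: all three sit at the same limit, (the limit of > 27000 nM in this assay, at which 3 of the 3 values shown sit), and no step between any pair of measured compounds can be computed.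

The next compound, compound 4, `CC(C)N(C(=O)C1CCN(C(=O)c2ccc(S(C)(=O)=O)c([N+](=O)[O-])c2)CC1)C(C)C`, differs from compound 3 in one place: diisopropylamino in place of (2-fluorobenzyl)(methyl)amino on a carbonyl carbon whose other neighbour is a saturated ring carbon. Nothing measured in this assay connects such a change to a shift in the read-out; the three results so far give no direction at all. For compound 4 the expectation is no step beyond the scatter, with the estimated change from compound 3 to compound 4 being a step that the limit leaves unreadable from compound 3 to compound 4. Compound 4 is expected to come out at around 40000 nM, within 18000 nM to 150000 nM, most likely again as a limit rather than a number.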

Compound 4, half-maximal effective concentration: > 27000 nM
Compound 4 was reported as a limit (the forecaster's own chance of this, stated with the estimate: 85%); the middle value does not contradict the limit.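

In this assay, within the data shown here, compound 4 gives > 27000 nM as a limit and not a number, so no step from compound 3 to compound 4 can be read. All compounds in the series share one limit: the limit of > 27000 nM in this assay, at which 4 of the 4 values shown sit. The compounds shown leave open whether diisopropylamino in place of (2-fluorobenzyl)(methyl)amino changes the read-out at all, and at what concentration any of them reaches the half-maximal effect.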